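A few compounds are considered here, and "the series" means these few. Any claim that something is new, unique, unknown or untested is made for them only; others in the source may bear on it.

Compound 2 `CCCS(=O)(=O)Nc1cccc2c1CCCC2c1c[nH]cn1` carries a propylsulfonyl group on the shared core, and in an assay on isolated protein for binding affinity to Alpha-1A adrenergic receptor (Rattus norvegicus), read by radioligand binding (on this read-out higher numbers stand for weaker inhibition and lower numbers for stronger inhibition), compound 2 gives 1700 nM. Compound 3 `CS(=O)(=O)Nc1cccc2c1CCCCC2c1c[nH]cn1` carries a methylsulfonyl group on a core that differs elsewhere, and in this assay compound 3 gives 1350 nM, a number within the usual scatter of compound 2. Compound 1 `CS(=O)(=O)Nc1ccc(Cl)c2c1CCCC2c1c[nH]cn1` also carries a methylsulfonyl group and differs elsewhere again, and in this assay compound 1 gives 447 nM, a number beyond the scatter below that of compound 2. Compound 4 `CCS(=O)(=O)Nc1cccc2c1CCCC2c1c[nH]cn1` has not yet been measured. It differs from compound 2 by hydrogen in place of methyl on a saturated chain carbon, two bonds along the chain from a sulfonyl sulfur, which read one bond further out is propylsulfonyl to ethylsulfonyl. Among the measured compounds shown here, no measured pair isolates this change, so its size is not known. Because compound 1 at 447 nM sits beyond the scatter below compound 2 while each methylsulfonyl compound also differs elsewhere, a modest step toward a lower number is expected from compound 2 to compound 4, a 1.7-fold lower number from compound 2 to compound 4 (0.23 log units; within the scatter). Compound 4 is therefore estimated at 1000 nM, with a range from 400 nM to 2500 nM.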

Compound 4, inhibition constant: 46.8 nM
For compound 4 the middle estimate is 21-fold (1.33 log units) above the measured one, and the stated range ends above it.
By their numbers in this assay, from the lowest: compound 4; then compound 1; then compounds 3 and 2 (each within the scatter of the next).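

In this assay the change from propylsulfonyl to ethylsulfonyl comes with a 36-fold lower number from compound 2 to compound 4 (1.56 log units; beyond the scatter) and is the first pair shown that isolates this position. Hydrogen in place of methyl on a saturated chain carbon, two bonds along the chain from a sulfonyl sulfur, is therefore a change of a single carbon atom with a large effect on the number in this assay. No evidence given here accounts for the size of this step.

The compounds shown leave open how a butylsulfonyl chain or an amine at the end of the chain would read on the shared core, and whether a methylsulfonyl group there would extend the step or reverse it. Compound 1 and compound 3 carry methylsulfonyl but differ elsewhere, so neither settles this.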